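Replacing the acyl group on the amide: ethyl at compound 3

The source may report more compounds than this note shows. Statements on the series, on what has been measured and on what is new or still open speak of the compounds shown alone.

Measured in a physicochemical assay for solubility, read by LC-MS, in phosphate buffer, with a stated time of 24 h, at pH 6.8; on this read-out lower numbers stand for lower solubility and higher numbers for higher solubility:
- compound 1 `C[C@H](NC(=O)C1CCOCC1)c1ccc(NC(=O)N2CC(c3cncc(N)c3)C2)cc1`: 440000 nM
- compound 2 `C[C@H](NC(=O)[C@@H]1CCCN1C)c1ccc(NC(=O)N2CC(c3cncc(N)c3)C2)cc1`: 820000 nM

Going by the values given here, compound 2 does not stand apart from the only other measured compound, as the two numbers lie within the scatter of each other.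

Compound 3 `CCC(=O)N[C@@H](C)c1ccc(NC(=O)N2CC(c3cncc(N)c3)C2)cc1` carries ethyl in place of 1-methylpyrrolidin-2-yl on a carbonyl carbon.

Among the compounds with values here, one measured step bears on this place, the exchange of oxan-4-yl for 1-methylpyrrolidin-2-yl: a 1.9-fold higher number from compound 1 to compound 2 (0.27 log units; within the scatter), within the scatter. Within the data shown here, it is a single pair, and no measured compound yet carries ethyl here, so the support is thin. No step beyond the scatter is expected in this assay, though the range is kept wide.

The expected change is a 1.5-fold lower number from compound 2 to compound 3 (0.17 log units; within the scatter).

For compound 3 the estimated value is 550000 nM, with an expected range of 250000 nM to 1100000 nM.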

Compound 3, solubility: 230000 nM
For compound 3 the middle estimate is 2.4-fold (0.38 log units) above the measured one; measured number below the stated range.
By their numbers in this assay, from the lowest: compounds 3, 1 and 2 (each within the scatter of the next, the first and the last beyond it).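

In this assay ethyl in place of 1-methylpyrrolidin-2-yl on a carbonyl carbon gives a 3.6-fold lower number from compound 2 to compound 3 (0.55 log units; beyond the scatter), a modest step and the first at this place to lie beyond the scatter. Ethyl in place of oxan-4-yl gives a 1.9-fold lower number from compound 1 to compound 3 (0.28 log units; within the scatter), so ethyl and oxan-4-yl are not separated here, and only the ethyl and 1-methylpyrrolidin-2-yl ends of the set stand apart. Nothing measured here accounts for the step.

Ethyl differs from 1-methylpyrrolidin-2-yl both in having no ring and in having no nitrogen, so these compounds cannot tell which of the two goes with the step. A cyclopentyl group, a dimethylaminomethyl group or a longer chain such as butyl on this carbonyl carbon would bear on that question.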